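Swapping a Para Fluoro for Methyl: Tolerability Estimate

A few compounds are considered here, and "the series" means these few. Any claim that something is new, unique, unknown or untested is made for them only; others in the source may bear on it.

For the measured compounds named here, compound 2 `CCCC[C@@H](CCn1cncn1)c1ccc(F)cc1` gives 36 ug/mL in an ADME assay on HEp-2 cells (Homo sapiens) for cytotoxicity, read by MTT assay, with a stated time of 3 days (a higher number here means that more compound is tolerated, a lower number that less compound is tolerated), the higher of the two numbers measured so far. Going by the values given here, the only comparison available is with compound 1 `CCCC[C@@H](CCn1cncn1)c1ccc(Cl)cc1`, which gives 17 ug/mL in this assay; the step of a 2.1-fold higher number from compound 1 to compound 2 (0.33 log units; beyond the scatter) is modest but beyond the scatter. Compound 3 `CCCC[C@@H](CCn1cncn1)c1ccc(C)cc1` differs from compound 2 by methyl in place of fluoro on an aromatic carbon. Among the compounds with values here, no measured step involves a methyl group, so the change from fluoro to methyl stands without a direct precedent; the one measured step, from chloro to fluoro, shows that the group at this position can shift the number by a modest amount. On that basis the step of a 1.4-fold lower number from compound 2 to compound 3 (0.16 log units; within the scatter) is expected to be small, possibly back toward the number seen for compound 1, and no large change is expected. Compound 3 is estimated to give 25 ug/mL in this assay, within a range from 12 ug/mL to 50 ug/mL.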

Compound 3, half-maximal cytotoxic concentration: 60.7 ug/mL
Estimate against measurement, compound 3: 2.4-fold (0.39 log units) below; measured number outside the range, above it.
By their numbers in this assay, from the lowest: compound 1; then compounds 2 and 3 (each within the scatter of the next).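

In this assay, methyl in place of fluoro gives a 1.7-fold higher number from compound 2 to compound 3 (0.23 log units; within the scatter), so these two groups cannot be told apart at this position. Methyl in place of chloro gives a 3.6-fold higher number from compound 1 to compound 3 (0.55 log units; beyond the scatter), and with the earlier step this sets chloro apart: compound 1 has the lowest number of the three, while compound 2 and compound 3 sit together, so the new result shows that chloro is the one group of the three that differs measurably here. Nothing available explains why chloro stands apart from the other two groups.

The compounds shown leave open how this position would respond to quite different groups, such as a methoxy group, an amine or a carboxylic acid. They also leave open whether the same order of groups would hold with a longer chain on the shared core.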